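This account rests on a few compounds, and the source may have more. Where it says the series, first, only, none or still open, it means among the compounds named here.

Working notes on the series.

Of the compounds shown here, two have been measured in a physicochemical assay for lipophilicity, measured as octanol-water partition; a lower number here means a more polar compound, a higher number a more lipophilic compound. Compound 1, `CCCOc1c(Cl)cc(N/C=N/OCC)cc1Cl`, gives 4.6 in this assay. Compound 2, `C#CCc1c(Cl)cc(N/C=N/OCC=C)cc1Cl`, gives 3.7 in this assay. Compound 2 thus stands lowest of the two numbers; its nearest neighbour is compound 1, whose value lies higher by a gap beyond the usual scatter.

The next compound, compound 3, `C#CCc1c(Cl)cc(N/C=N/OCCCl)cc1Cl`, has not yet been measured in this assay. Set against compound 2, the structural change is chloromethyl in place of vinyl on a saturated chain carbon bound to an oxygen. The group that leaves and the group that enters are of the same size in heavy atoms, and neither carries a hydrogen-bond donor or acceptor. Among the compounds with values here, nothing among the measured pairs isolates this kind of change, so the expectation rests on the nature of the swap alone. The step of no change at the digits printed from compound 2 to compound 3 (within the scatter) is expected to be none beyond the scatter, in either direction. Compound 3 is therefore estimated at 3.7 in this assay, with a range from 3.3 to 4.1.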

Compound 3, partition coefficient: 3.7
The estimate for compound 3 equals the measured number at the digits printed; measured number inside the range.
By their numbers in this assay, from the lowest: compounds 2 and 3 (each within the scatter of the next); then compound 1.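

Chloromethyl in place of vinyl on a saturated chain carbon bound to an oxygen gives no change at the digits printed from compound 2 to compound 3 (within the scatter) in this assay, and this is the only pair shown that differs in one place. At this position, allyloxy and 2-chloroethoxy therefore cannot be told apart by this read-out, even though the double bond outside aromatic rings is gone and a chlorine has entered at the same count of heavy atoms. Nothing measured beyond the partition numbers bears on why the two compounds read alike.

On these data alone, whether the same holds for an amine, a carboxylic acid or a longer chain on a saturated chain carbon bound to an oxygen stays open. Compound 1 differs from compound 2 and compound 3 in more than one place, so it offers no comparison for this position.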